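Swapping the Aryl Amine on a Fused Bicyclic Core

The compounds below may be only part of what the source reports. "The series", "measured", "known", "first", "only" and "open" are said of these compounds alone.

Measured compounds:
compound 1 `Cc1cc(-c2ccc(F)cc2)cc(C)c1Oc1nc(Nc2ccc(C#N)nc2)nc2ccsc12`, in a toxicity assay on MT4 cells (Homo sapiens) for cytotoxicity, read by MTT assay, with a stated time of 5 days (a higher number here means that more compound is tolerated, a lower number that less compound is tolerated), compound 1 gives 6130 nM
compound 2 `Cc1cc(-c2ccc(F)cc2)cc(C)c1Oc1nc(Nc2ccc(C#N)nc2)nc2sccc12`, in this assay compound 2 gives 2230 nM
compound 3 `N#C/C=C/c1cc(F)c(Oc2nc(Nc3ccc(C#N)c(F)c3)nc3c2COC3)c(F)c1`, in this assay compound 3 gives 243000 nM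

Compound 3 stands highest of the three numbers in this assay. Its nearest neighbour is compound 1, whose number is lower by a gap beyond the scatter, and the widest gap separates it from compound 2, also beyond the scatter. Among the measured compounds shown here, compounds 1 and 2 share a core unlike that of compound 3, so no single-change step links either of them to compound 3; their values show only that both carry the (6-cyanopyridin-3-yl)amino and sit far lower than compound 3.

Compound 4 `N#C/C=C/c1cc(F)c(Oc2nc(Nc3ccc(C#N)nc3)nc3c2COC3)c(F)c1` is compound 3 with 6-cyanopyridin-3-yl in place of 4-cyano-3-fluorophenyl on a nitrogen on an aromatic ring, the (4-cyano-3-fluorophenyl)amino becoming a (6-cyanopyridin-3-yl)amino. For the measured compounds named here, no measured pair isolates this change on the core of compound 3, so the expectation rests on compound 3 alone. In this assay the expected step is a 1.6-fold lower number from compound 3 to compound 4 (0.21 log units; within the scatter), a modest move downward that may well fall within the scatter. Compound 4 is therefore estimated at 150000 nM, within a range from 50000 nM to 400000 nM.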

Compound 4, half-maximal cytotoxic concentration: 243000 nM
Beside the measured number, compound 4's estimate is 1.6-fold (0.21 log units) below it; low and high end bracket the measured number.
By their numbers in this assay, from the lowest: compound 2; then compound 1; then compounds 3 and 4 (each within the scatter of the next).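

In this assay the swap of 4-cyano-3-fluorophenyl for 6-cyanopyridin-3-yl on a nitrogen on an aromatic ring gives no change at the digits printed from compound 3 to compound 4 (within the scatter), so on the core of compound 3 this position accepts the change without a step beyond the scatter. Among the compounds shown here, the earlier compounds could not show this: the (6-cyanopyridin-3-yl)amino had stood only on the core of compound 1 and compound 2, and no single-change step existed, so this is the first reading of that group on the core of compound 3 and the first direct reading of this swap. Nothing on hand bears on why the number holds at the digits printed.

On these data alone, whether the same swap behaves alike on the core of compound 1 and compound 2 stays open, since neither appears here with a 4-cyano-3-fluorophenyl. Also open, as far as these compounds go, is how far this tolerance extends on the core of compound 3, for instance to a plain phenyl, a 4-methoxyphenyl or a pyrimidine ring on that nitrogen.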